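Cyclopentyl to thiophen-3-yl on the thiophene arm

A few compounds are considered here, and "the series" means these few. Any claim that something is new, unique, unknown or untested is made for them only; others in the source may bear on it.

Compound 1, `CCc1ccsc1CN[C@@H]1C[C@H]2C[C@@H]([C@H]1C)C2(C)C`, gives 25000 nM in an ADME assay on MDCK cells (Canis lupus familiaris) for cytotoxicity, read by microscopy, with a stated time of 48 h; on this read-out higher numbers stand for lower toxicity in this test and lower numbers for higher toxicity in this test.
Compound 2, `C[C@H]1[C@H](NCc2sccc2C2CCCC2)C[C@H]2C[C@@H]1C2(C)C`, gives 12500 nM in this assay.
Compound 3, `C[C@H]1[C@H](NCc2cnccn2)C[C@H]2C[C@@H]1C2(C)C`, reaches only the limit > 100000 nM in this assay, which is a limit of the assay and not a number.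

Among the three compounds, compound 2 holds the lowest of the two plain numbers in this assay; its nearest neighbour is compound 1, and the step of a 2.0-fold lower number from compound 1 to compound 2 (0.30 log units; within the scatter) is within the scatter. The value of compound 3 is a limit of > 100000 nM in this assay, at which 1 of the 3 values shown sits, and gives no number to compare.

Compound 4, `C[C@H]1[C@H](NCc2sccc2-c2ccsc2)C[C@H]2C[C@@H]1C2(C)C`, has not yet been measured in this assay. It differs from compound 2 in one place: thiophen-3-yl in place of cyclopentyl on an aromatic carbon. The exchange sits on an aromatic carbon of the five-membered aromatic ring with one sulfur, where compound 2 carries the cyclopentyl.

Among the compounds with values here, only one measured step touches this position, the change from ethyl to cyclopentyl on that aromatic carbon, and a 2.0-fold lower number from compound 1 to compound 2 (0.30 log units; within the scatter) stayed within the scatter. With a second group of the same atom count now entering at the same place, no step beyond the scatter is expected in this assay in either direction. The step from compound 2 is therefore estimated as a 1.2-fold higher number from compound 2 to compound 4 (0.08 log units; within the scatter). Compound 4 is expected to give about 15000 nM, within a range from 6000 nM to 50000 nM.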

Compound 4, minimum cytotoxic concentration: 12500 nM
Compound 4: middle estimate off by 1.2-fold (0.08 log units), on the high side; measured number inside the range.
By their numbers in this assay, from the lowest: compounds 2, 4 and 1 (each within the scatter of the next). At a limit, above all of these: compound 3.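

In this assay, the aromatic carbon now carries a third group, and the read-out does not separate it from the other two: thiophen-3-yl in place of cyclopentyl gives no change at the digits printed from compound 2 to compound 4 (within the scatter), and thiophen-3-yl in place of ethyl gives a 2.0-fold lower number from compound 1 to compound 4 (0.30 log units; within the scatter). Until now this place had been probed only with groups of carbon alone, whereas the entering group brings a five-membered aromatic ring with a sulfur and one hydrogen-bond acceptor, where cyclopentyl has none. Among compounds 1, 2 and 4, then, neither the exchange of a non-aromatic ring for an aromatic one nor the arrival of that hetero atom moves the number beyond the scatter.

Within the data shown here, compound 3 carries a different arm on the shared core and stands at a limit of the assay, not a number, so it gives no step to set beside these: the limit of > 100000 nM in this assay, at which 1 of the 4 values shown sits. How an amine, a carboxylic acid or a chain longer than ethyl on this aromatic carbon would read in this assay remains open.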